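Amide nitrogen substituent changes in the dodecyl-tetrazole series

The source may hold more compounds than are shown below. What is called first, only, known or untested is meant among the compounds shown, and "the series" means these compounds.

Measured so far:
compound 1 `CCCCCCCCCCCCn1nnc(C(C(=O)Nc2ccc(F)cc2F)c2ccccc2)n1` — 31 nM
compound 2 `CCCCCCCCCCCCn1nnc(C(C(=O)Nc2ncccc2C)c2ccccc2)n1` — 85 nM
compound 3 `CCCCCCCCCCCCn1nnc(C(C(=O)Nc2c(OC)ncnc2OC)c2ccccc2)n1` — 13 nM

In an assay on liver for inhibition of sterol O-acyltransferase 1 (Rattus norvegicus), using microsomes (on this read-out higher numbers stand for weaker inhibition and lower numbers for stronger inhibition), compound 2 stands highest of the three numbers, so weakest of the three; its nearest neighbour is compound 1 (a 2.7-fold higher number from compound 1 to compound 2 (0.44 log units; beyond the scatter)) and the furthest is compound 3 (a 6.5-fold lower number from compound 2 to compound 3 (0.82 log units; beyond the scatter)). Compound 1 to compound 3 gives a 2.4-fold lower number from compound 1 to compound 3 (0.38 log units; beyond the scatter).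

Compound 4 `CCCCCCCCCCCCn1nnc(C(C(=O)NC2CC2)c2ccccc2)n1` differs from compound 2 in one place: cyclopropyl in place of 3-methylpyridin-2-yl on an amide-type nitrogen.

The three measured steps all exchange one six-membered aromatic group for another on the amide-type nitrogen; each is modest, and the spread they cover runs from compound 2 at the top to compound 3 at the bottom. Within the data shown here, none of them removes the aromatic ring altogether, so no measured step bears directly on the change to compound 4. Without a precedent, the expectation for compound 4 is a move in the direction of a higher number, meaning weaker inhibition, with a wide margin on both sides, and this is an estimate rather than an observation: a 3.5-fold higher number from compound 2 to compound 4 (0.55 log units; beyond the scatter).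

Compound 4 is therefore expected at about 300 nM in this assay, within a range from 60 nM to 2000 nM.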

Compound 4, half-maximal inhibitory concentration: 244 nM
Compound 4: middle estimate off by 1.2-fold (0.09 log units), on the high side; the range from low to high includes it.
By their numbers in this assay, from the lowest: compound 3; then compound 1; then compound 2; then compound 4.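

In this assay, an aromatic ring on the amide-type nitrogen is not needed for measurable inhibition, as compound 4 with its cyclopropyl group still gives 244 nM and is nonetheless the weakest of the four. Among these compounds, the cost of replacing the aromatic group depends on which group leaves: the comparisons show a 2.9-fold higher number from compound 2 to compound 4 (0.46 log units; beyond the scatter) and a 7.9-fold higher number from compound 1 to compound 4 (0.90 log units; beyond the scatter) and, as the only step here rated large, a 19-fold higher number from compound 3 to compound 4 (1.27 log units; beyond the scatter) so the loss is smallest for 3-methylpyridin-2-yl and greatest for the group carried by compound 3. No available evidence bears on what lies behind these differences.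

The change to cyclopropyl removes the aromatic ring and reduces the size of the group in a single step, and these four compounds cannot separate the two changes, so a cyclohexyl group on the amide-type nitrogen would be the informative comparison. All four compounds also share the dodecyl chain and the rest of the core, which leaves open whether the order seen here would hold with a shorter chain such as octyl.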